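Exchanging the aromatic group of compound 2

This account rests on a few compounds, and the source may have more. Where it says the series, first, only, none or still open, it means among the compounds named here.

For the measured compounds named here, in a functional assay on the whole organism with Rattus norvegicus as the target (on this read-out lower numbers stand for an effect already at smaller amounts and higher numbers for an effect only at larger amounts of compound), compound 2 `CSc1cc(C)nc(Cl)c1NC(=O)N(Cc1ccc(Oc2ccc(F)cc2)cc1)C1CCCCCC1` gives 0.022 mg/kg, the only exact number so far. Compound 1 `COc1nc(C)cc(SC)c1NC(=O)N(Cc1ccc(Oc2ccc(F)cc2)cc1)C1CCCCCC1` is known only as a limit, < 0.032 mg/kg. Compound 3 `COc1nc(C)ccc1NC(=O)N(Cc1ccc(Oc2ccc(F)cc2)cc1)C1CCCCCC1` has not yet been measured, and its change is a group of 9 heavy atoms (7 carbon, 1 nitrogen, 1 oxygen; one six-membered aromatic ring with 1 hetero atom) in place of a group of 10 heavy atoms (7 carbon, 1 nitrogen, 1 sulfur, 1 chlorine; one six-membered aromatic ring with 1 hetero atom), on an amide-type nitrogen. Going by the values given here, the one measured step is a step that the limit leaves unreadable from compound 1 to compound 2, and it covers only chloro in place of methoxy. Among the compounds with values here, no measured step covers the loss of the sulfur-bearing part of the group. The expected step is a 4.5-fold higher number from compound 2 to compound 3 (0.66 log units; beyond the scatter), towards a larger dose in this assay. Compound 3 is estimated at 0.1 mg/kg, with an expected range from 0.03 mg/kg to 0.4 mg/kg.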

Compound 3, dose for half-maximal effect: > 0.1 mg/kg
Compound 3: a limit, no number (the forecaster's own chance of this, stated with the estimate: 15%); the middle value lies on the limit itself.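

In this assay compound 3 is known only as a limit, > 0.1 mg/kg. Hydrogen in place of methylsulfanyl on an aromatic carbon, a single change, gives an at least 3.1-fold higher number from compound 1 to compound 3 (0.49 log units; beyond the scatter), so this group matters for the dose, which the earlier compounds could not show. The exchange of the whole aromatic group gives an at least 4.5-fold higher number from compound 2 to compound 3 (0.65 log units; beyond the scatter), and neither step has a readable upper size.

From the compounds shown here alone, whether a methyl, an ethylsulfanyl or an amine on this carbon would keep the small dose remains open. The step from compound 1 to compound 2 cannot be read.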